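The source may hold more compounds than are shown below. What is called first, only, known or untested is meant among the compounds shown, and "the series" means these compounds.

Measured compounds in this series:
compound 1 `CC(C)c1ccc(-c2nc(SCc3cn(CC(=O)NC(=O)Nc4ccccn4)nn3)nc(Nc3ccc(Cl)cc3)c2C#N)cc1` gives 11200 nM in a functional assay on ECa-109 cells (Homo sapiens) for inhibition, read by MTT assay, with a stated time of 72 h; on this read-out lower numbers stand for stronger inhibition and higher numbers for weaker inhibition;
compound 2 `CC(C)c1ccc(-c2nc(SCc3cn(CC(=O)NC(=O)Nc4ccccn4)nn3)nc(Nc3cccc(C(F)(F)F)c3)c2C#N)cc1` gives 24200 nM;
compound 3 `COc1ccc(Nc2nc(SCc3cn(CC(=O)NC(=O)Nc4ccccn4)nn3)nc(-c3ccc(C(C)C)cc3)c2C#N)cc1` gives 5420 nM.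

Compound 1 stands second highest of the three numbers. Its nearest neighbour is compound 3, a step of a 2.1-fold lower number from compound 1 to compound 3 (0.32 log units; beyond the scatter); the furthest is compound 2, a step of a 2.2-fold higher number from compound 1 to compound 2 (0.33 log units; beyond the scatter). Between the two ends, compound 2 to compound 3 runs a 4.5-fold lower number from compound 2 to compound 3 (0.65 log units; beyond the scatter).

Compound 4 `Cc1ccc(Nc2nc(SCc3cn(CC(=O)NC(=O)Nc4ccccn4)nn3)nc(-c3ccc(C(C)C)cc3)c2C#N)cc1` is not yet measured. It differs from compound 1 by methyl in place of chloro on an aromatic carbon. The step that bears most directly on it is compound 1 to compound 3, where methoxy in place of chloro on the same aromatic carbon gave a modest lowering of the number. The other two steps swap the whole aryl group on the nitrogen and speak less directly to a single-atom exchange at that carbon. Methyl is neither chloro nor methoxy, so the expectation is a small step at most, likely toward a lower number, and quite possibly within the scatter.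

Compound 4 is therefore expected to give about 8000 nM in this assay, in a range from 4000 nM to 16000 nM, which is estimated as a step of a 1.4-fold lower number from compound 1 to compound 4 (0.15 log units; within the scatter).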

Compound 4, half-maximal inhibitory concentration: 6700 nM
Beside the measured number, compound 4's estimate is 1.2-fold (0.08 log units) above it; low and high end bracket the measured number.
By their numbers in this assay, from the lowest: compounds 3, 4 and 1 (each within the scatter of the next, the first and the last beyond it); then compound 2.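

In this assay, methyl in place of chloro on this aromatic carbon gives a 1.7-fold lower number from compound 1 to compound 4 (0.22 log units; within the scatter), and methyl in place of methoxy gives a 1.2-fold higher number from compound 3 to compound 4 (0.09 log units; within the scatter). The methyl group thus leaves compound 4 within the scatter of both compound 1 and compound 3, although those two lie beyond the scatter of each other, so the three groups at this carbon do not resolve into a clear order. The exchange of 3-(trifluoromethyl)phenyl for 4-methylphenyl gives a 3.6-fold lower number from compound 2 to compound 4 (0.56 log units; beyond the scatter), which places a third 4-substituted phenyl, after those of compound 1 and compound 3, beyond the scatter of compound 2, though that exchange alters both the group and where it sits. Nothing shown here offers an explanation for these numbers.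

Still open, as far as these compounds go, is whether an amine, a hydroxyl or a carboxylic acid on this aromatic carbon would move the number beyond the scatter of compound 4, and whether a longer chain such as propyl would do so. Also open, from the compounds shown here alone, is whether methyl or chloro placed where the trifluoromethyl sits in compound 2 would match that compound or the 4-substituted compounds.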